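Swapping One Side Chain on a Shared Core

This account rests on a few compounds, and the source may have more. Where it says the series, first, only, none or still open, it means among the compounds named here.

Measured so far in a functional assay on PBMC cells (Homo sapiens) for inhibition; a higher number here means a weaker inhibitor, a lower number a stronger inhibitor:
- compound 1, `N=C(N)NCCC[C@H](N)C(=O)NS(=O)(=O)OC[C@H]1OC[C@@H](n2cnc3c(N)ncnc32)C[C@@H]1O`, gives 600 nM
- compound 2, `Nc1ncnc2c1ncn2[C@@H]1CO[C@H](COS(=O)(=O)NC(=O)[C@@H]2CCCN2)[C@@H](O)C1`, gives 2800 nM
- compound 3, `CSCC[C@H](N)C(=O)NS(=O)(=O)OC[C@H]1OC[C@@H](n2cnc3c(N)ncnc32)C[C@@H]1O`, gives 5500 nM

Compound 3 has the highest number of the three. Its gap to compound 2, a 2.0-fold higher number from compound 2 to compound 3 (0.29 log units; within the scatter), falls within the scatter, so the two cannot be ranked against each other; its gap to compound 1, a 9.2-fold higher number from compound 1 to compound 3 (0.96 log units; beyond the scatter), is beyond the scatter, so compound 1 is the clearly stronger inhibitor of the pair.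

Compound 4, `CC(C)C[C@H](N)C(=O)NS(=O)(=O)OC[C@H]1OC[C@@H](n2cnc3c(N)ncnc32)C[C@@H]1O`, is the next step from compound 3. The change is isopropyl in place of (methylsulfanyl)methyl on a saturated chain carbon, two bonds along the chain from an amine nitrogen and a carbonyl carbon. Among the measured compounds shown here, no measured step alters this exact position. The closest guide is the step from compound 1 to compound 3, which also changed a side chain on a saturated chain carbon near the amine nitrogen and the carbonyl carbon and gave a modest step. The step from compound 2 to compound 3, a larger rearrangement of that side chain, stayed within the scatter. Both side chains here lack hydrogen-bond donors and charge, so a step no larger than modest is expected, direction uncertain, for a 1.1-fold lower number from compound 3 to compound 4 (0.04 log units; within the scatter). Compound 4 is therefore estimated at 5000 nM, with a range from 1500 nM to 16000 nM.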

Compound 4, half-maximal inhibitory concentration: 6800 nM
Beside the measured number, compound 4's estimate is 1.4-fold (0.13 log units) below it; low and high end bracket the measured number.
By their numbers in this assay, from the lowest: compound 1; then compounds 2, 3 and 4 (each within the scatter of the next, the first and the last beyond it).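

In this assay, putting isopropyl in place of (methylsulfanyl)methyl on a saturated chain carbon, two bonds along the chain from an amine nitrogen and a carbonyl carbon, gives a 1.2-fold higher number from compound 3 to compound 4 (0.09 log units; within the scatter) and so no readable change, which means the sulfur-bearing and all-carbon side chains cannot be told apart here. Among the compounds shown here, compound 4 also adds two wider comparisons: there is a 2.4-fold higher number from compound 2 to compound 4 (0.39 log units; beyond the scatter) and, against the side chain of compound 1, an 11-fold higher number from compound 1 to compound 4 (1.05 log units; beyond the scatter) as the first step in this set to be rated large, while compound 1 stays clearly apart from each of the other three compounds. Nothing available accounts for these differences in the numbers.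

From the compounds shown here alone, whether a chain ending in an amine, or one ending in a carboxylic acid, could come close to compound 1 at 600 nM in this assay remains open. Also open, going by these compounds, is whether a phenyl group on this chain carbon would stay level with compound 3 and compound 4 or move clearly away from them.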